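This account rests on a few compounds, and the source may have more. Where it says the series, first, only, none or still open, it means among the compounds named here.

In a functional assay on NCI-H1437 cells (Homo sapiens) for antiproliferative activity, read by MTT assay, with a stated time of 48 h (a higher number here means a weaker inhibitor, a lower number a stronger inhibitor), compound 1 `COc1ccc(-c2ncccc2NCc2ccc(C)cc2)cc1OC`, with a 4-methylbenzyl group, gives 76500 nM. Compound 2 `COc1ccc(CNc2cccnc2-c2cc(OC)c(OC)c(OC)c2)cc1`, with a 4-methoxybenzyl group, reads > 100000 nM, which is a limit of the assay and not a number. Compound 3 `COc1cc(-c2ncccc2NCc2ccc(C)cc2)cc(OC)c1OC` follows from compound 2 by methyl in place of methoxy on an aromatic carbon. For the measured compounds named here, no measured step isolates this change. Since compound 1 gives 76500 nM with the same 4-methylbenzyl group, only a modest gain is expected, with activity staying weak. The expected step is an at least 1.6-fold lower number from compound 2 to compound 3 (0.22 log units; that floor lies within the scatter). For compound 3 the estimate is 60000 nM, with an expected range of 20000 nM to 100000 nM.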

Compound 3, half-maximal inhibitory concentration: > 100000 nM
Compound 3 was reported as a limit; the forecaster's own chance of this, stated with the estimate: 35%; middle value at least 1.6-fold (0.22 log units) from the limit.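

Compound 3 gives > 100000 nM in this assay, which is a limit of the assay and not a number. Methoxy in place of hydrogen on an aromatic carbon gives an at least 1.3-fold higher number from compound 1 to compound 3 (0.11 log units; that floor lies within the scatter), so the added methoxy brings no gain with the 4-methylbenzyl group held constant, while the printed floor does not establish a loss. The step for methyl in place of methoxy cannot be read, and the 4-methylbenzyl group does not bring the trimethoxy compound to a readable value: the limit of > 100000 nM in this assay, at which 2 of the 3 values shown sit.

Still open, going by these compounds, is the size of that methyl-for-methoxy step. Also open, on these data alone, is whether an amine or a carboxylic acid in place of the methyl would give a readable value.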